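The source may report more compounds than this note shows. Statements on the series, on what has been measured and on what is new or still open speak of the compounds shown alone.

In a functional assay on the whole organism (Tail, strain ICR) with Mus musculus as the target, in the tail flick test, with a stated time of 30 min, at a dose of 25 umol/kg by the oral route (a lower number here means a weaker effect, a higher number a stronger effect of the compound at the dose given), three compounds have been measured so far. Compound 1 `NC(=O)CC[C@H](NC(=O)CN(c1ncnc2c1ncn2C1CCCCO1)C1CC1)C(=O)OCc1ccccc1` gives 47%, compound 2 `CC(C)[C@H](NC(=O)CN(c1nc(Cl)nc2[nH]cnc12)C1CC1)C(=O)OCc1ccccc1` gives 33.4%, and compound 3 `NC(=O)C[C@H](NC(=O)CN(c1nc(Cl)nc2[nH]cnc12)C1CC1)C(=O)O` gives 29.7%. Compound 2 thus stands second highest of the three: its number sits within the usual scatter of that of compound 3, so no order between those two can be read, while compound 1 lies above compound 2 by a gap beyond the scatter.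

Compound 4 `NCCCC[C@H](NC(=O)CN(c1nc(Cl)nc2[nH]cnc12)C1CC1)C(=O)OCc1ccccc1` has not yet been measured in this assay. It differs from compound 2 in one place: 4-aminobutyl in place of isopropyl on a saturated chain carbon bound to an amide-type nitrogen and a carbonyl carbon. Going by the values given here, no pair of measured compounds shows the effect of such a change by itself; compound 1 and compound 3 differ from compound 2 in more places than one, so their numbers give no direction. A small step, a number 1.6 percentage points higher from compound 2 to compound 4 (within the scatter), is therefore expected in this assay, one that may fall on either side and stay within the usual scatter. Compound 4 is expected to give about 35% in this assay, with a range from 18% to 55%.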

Compound 4, a percentage reported as activity, at one dose (the size of the read-out at that dose, not a potency): 26.1%
The estimate for compound 4 lay 8.9 percentage points above the measured number; the measured number falls inside the stated range.
By their numbers in this assay, from the lowest: compounds 4, 3 and 2 (each within the scatter of the next); then compound 1.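

In this assay, putting 4-aminobutyl in place of isopropyl on the saturated chain carbon gives a number 7.3 percentage points lower from compound 2 to compound 4 (within the scatter), so the two compounds cannot be told apart. Going by these compounds alone, this is the first direct reading of a single change: at this position, a longer chain carrying an amine, with a hydrogen-bond donor and acceptor that isopropyl lacks, leaves the read-out at this one dose within the usual scatter. Nothing measured here explains this outcome.

The compounds shown do not separate the length of the chain from its amine, which a plain butyl group at the same position could do. Nor do they show whether a chain ending in a carboxylic acid in place of the amine would give a similar read-out.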